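Phenyl for methyl on the selenium-containing ring

The source may report more compounds than this note shows. Statements on the series, on what has been measured and on what is new or still open speak of the compounds shown alone.

Measured compounds:
compound 1 `NC(=[Se])N/N=C/c1ccc(Cl)cc1` gives 13000 nM
compound 2 `Cc1c[se]c(N/N=C/c2ccc(Cl)cc2)n1` gives 56500 nM
compound 3 `CC(=O)N(/N=C/c1ccc(Cl)cc1)c1nc(C)c[se]1` gives 59200 nM

All three values come from a functional assay on HepG2 cells (Homo sapiens) for cytotoxicity, read by XTT assay, with a stated time of 72 h; a higher number here means a weaker inhibitor, a lower number a stronger inhibitor. Compound 3 stands at the top end of the numbers shown, but compound 2 sits within the scatter of it, so no order between those two can be read. Compound 1 lies further off, with a lower number than compound 3. Going by the values given here, the only single-point step among the measured compounds is a 1.0-fold higher number from compound 2 to compound 3 (0.02 log units; within the scatter), and it touches a nitrogen, not the ring carbon in question.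

Compound 4 `CC(=O)N(/N=C/c1ccc(Cl)cc1)c1nc(-c2ccccc2)c[se]1` differs from compound 3 by phenyl in place of methyl on an aromatic carbon. Among the compounds with values here, no measured step bears on this change, so nothing in the data points in either direction. Compound 4 is therefore expected to sit close to compound 3 in this assay, with a step of about a 1.3-fold lower number from compound 3 to compound 4 (0.12 log units; within the scatter) and a wide margin either way. The estimate for compound 4 is 45000 nM, with a range from 15000 nM to 150000 nM.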

Compound 4, half-maximal inhibitory concentration: > 62000 nM
Compound 4: only a limit was reported; the forecaster's own chance of this, stated with the estimate: 20%; middle value at least 1.3-fold (0.13 log units) away from the limit.
By their numbers in this assay, from the lowest: compound 1; then compounds 2 and 3 (each within the scatter of the next). At a limit, above all of these: compound 4.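

In this assay compound 4 gives > 62000 nM, which is a limit of the assay and not a number. Going by these compounds alone, compound 2 and compound 3 carry methyl on this aromatic carbon, so phenyl gives the first reading for another group at this position, and the change yields an at least 1.0-fold higher number from compound 3 to compound 4 (0.02 log units; that floor lies within the scatter). Only a floor for this step is known, and it shows no lower number with phenyl, while the size of any rise stays unknown: the limit of > 62000 nM in this assay, at which 1 of the 4 values shown sits.

The compounds shown leave open whether an amine, a carboxylic acid or an ethyl group on this carbon would give a lower number. They also leave open whether phenyl would behave the same way with hydrogen in place of acetyl on the nitrogen, as in compound 2.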